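Swapping a Piperidinylmethyl for an Ethoxycarbonyl on the Core

The source may report more compounds than this note shows. Statements on the series, on what has been measured and on what is new or still open speak of the compounds shown alone.

Measured compounds:
Compound 1: `CCNC(=O)c1noc(-c2cc(C(C)C)c(O)cc2O)c1-c1cc(COCC(=O)O)no1` — in a functional assay on A2780 cells (Homo sapiens) for inhibition (a higher number here means a weaker inhibitor, a lower number a stronger inhibitor), compound 1 stands as "not determined" (no result reported), so no result was reported.
Compound 2: `CCNC(=O)c1noc(-c2cc(C(C)C)c(O)cc2O)c1-c1cc(CN2CCCCC2)no1` — 62 nM in this assay.

Both compounds share one core and differ only in the group carried on the five-membered aromatic ring with one nitrogen and one oxygen. Compound 1 has no number attached to it, so nothing can be said of its strength. Compound 2 is therefore the only compound with a value; on the numbers shown it stands alone and cannot be ranked against anything else.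

Compound 3 (`CCNC(=O)c1noc(-c2cc(C(C)C)c(O)cc2O)c1-c1cc(C(=O)OCC)no1`) is the same molecule except for one change, (ethoxycarbonyl in place of (piperidin-1-yl)methyl on an aromatic carbon). Going by the values given here, no step between two measured compounds exists to learn from, so the expected size of a 2.4-fold higher number from compound 2 to compound 3 (0.38 log units; beyond the scatter) rests on this change alone. A modest weakening in this assay is expected, perhaps a little beyond the scatter, though a result within the scatter of compound 2 would not be surprising. Compound 3 is estimated at 150 nM, with a likely range from 40 nM to 600 nM.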

Compound 3, half-maximal inhibitory concentration: 9000 nM
The estimate for compound 3 lay 60-fold (1.78 log units) below the measured number, outside the stated range (above it).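

In this assay, the group on this aromatic carbon, next to the ring nitrogen, clearly matters: the change gives a 150-fold higher number from compound 2 to compound 3 (2.16 log units; beyond the scatter), a large step well beyond the scatter. Going by these compounds alone, this is the first sign that the position is not indifferent to what it carries, since the earlier compounds offered only one number and no comparison. The change replaces a group holding a six-membered non-aromatic ring and a nitrogen with an open group holding a carbonyl and no ring or nitrogen, but nothing shown identifies which of these differences accounts for the step.

Within the data shown here, with only one step, the ring, the nitrogen and the ethoxycarbonyl group cannot be separated, and a single pair cannot show whether the (piperidin-1-yl)methyl group is especially favourable or the ethoxycarbonyl group especially unfavourable. A (morpholin-4-yl)methyl group or an open-chain dimethylaminomethyl group at this position would test whether the ring or the amine nitrogen tracks with the lower number, while a simple amide in place of the ester would test the role of the ethoxy part.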